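Benzylamino for benzyloxy on a carbonyl carbon

The compounds below may be only part of what the source reports. "The series", "measured", "known", "first", "only" and "open" are said of these compounds alone.

Values in an ADME assay on Huh-7 cells (Homo sapiens) for cytotoxicity, with a stated time of 72 h (on this read-out higher numbers stand for lower toxicity in this test and lower numbers for higher toxicity in this test), each one a limit:
compound 1 `COC(=O)CCCC(=O)n1c(=O)c(C)cn([C@@H]2O[C@H](CO[Si](C)(C)C(C)(C)C)[C@@]3(OS(=O)(=O)C=C3N)[C@H]2O[Si](C)(C)C(C)(C)C)c1=O`: > 100000 nM
compound 2 `CNC(=O)CCCC(=O)n1c(=O)c(C)cn([C@@H]2O[C@H](CO[Si](C)(C)C(C)(C)C)[C@@]3(OS(=O)(=O)C=C3N)[C@H]2O[Si](C)(C)C(C)(C)C)c1=O`: > 100000 nM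
compound 3 `Cc1cn([C@@H]2O[C@H](CO[Si](C)(C)C(C)(C)C)[C@@]3(OS(=O)(=O)C=C3N)[C@H]2O[Si](C)(C)C(C)(C)C)c(=O)n(C(=O)CCCC(=O)OCc2ccccc2)c1=O`: > 100000 nM

Compound 3 sits at > 100000 nM, which is a limit and not a number. The change to compound 4 `Cc1cn([C@@H]2O[C@H](CO[Si](C)(C)C(C)(C)C)[C@@]3(OS(=O)(=O)C=C3N)[C@H]2O[Si](C)(C)C(C)(C)C)c(=O)n(C(=O)CCCC(=O)NCc2ccccc2)c1=O` is benzylamino in place of benzyloxy on a carbonyl carbon. The closest measured parallel is a step that the two limits leave unreadable from compound 1 to compound 2, with methylamino in place of methoxy on a carbonyl carbon. Less direct are a step that the two limits leave unreadable from compound 1 to compound 3 and a step that the two limits leave unreadable from compound 2 to compound 3. Within the data shown here, the series so far shows only (the limit of > 100000 nM in this assay, at which 3 of the 3 values shown sit). Among the measured compounds shown here, with no sized step to carry over, no change beyond the scatter is expected, and no direction can be given. The expected step is a number no higher from compound 3 to compound 4 (the limit leaves the size open). Compound 4 is estimated at 100000 nM, with an expected range of 50000 nM to 200000 nM. Another limit is the likeliest report.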

Compound 4, half-maximal cytotoxic concentration: > 100000 nM
Compound 4 gave a limit, no number; the forecaster's own chance of this, stated with the estimate: 85%; the middle value sits exactly at the limit.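

Among these compounds, compounds 1, 2, 3 and 4 each give only a limit in this assay, so no step among them can be read: the limit of > 100000 nM in this assay, at which 4 of the 4 values shown sit. The compounds shown leave open how far methoxy, methylamino, benzyloxy and benzylamino on the carbonyl carbon differ in this assay.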